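Fluoro for chloro: expected cytotoxicity of compound 3

The source may hold more compounds than are shown below. What is called first, only, known or untested is meant among the compounds shown, and "the series" means these compounds.

Compound 1 `N#Cc1ccc2c(Oc3ccccc3OCCn3ccc(=O)[nH]c3=O)cc(F)cc2c1` gives > 100000 nM in an ADME assay on MT2 cells (Homo sapiens) for cytotoxicity, read by MTT assay (on this read-out lower numbers stand for higher toxicity in this test and higher numbers for lower toxicity in this test), which is a limit of the assay and not a number. For the measured compounds named here, compound 2 `N#Cc1ccc2c(Oc3ccc(Cl)cc3OCCn3ccc(=O)[nH]c3=O)cc(Cl)cc2c1` gives 20000 nM in this assay and stands as the only numeric value in the set; the other entry sits at the limit of > 100000 nM in this assay, at which 1 of the 2 values shown sits. Compound 3 `N#Cc1ccc2c(Oc3ccc(Cl)cc3OCCn3ccc(=O)[nH]c3=O)cc(F)cc2c1` is not yet measured and differs from compound 2 by fluoro in place of chloro on an aromatic carbon. Going by the values given here, no measured step between compounds is available, so the size of this step cannot be read off; a shift toward lower toxicity that may exceed the usual scatter is expected. Compound 3 is estimated at 50000 nM, between 20000 nM and 150000 nM, an expected step of a 2.5-fold higher number from compound 2 to compound 3 (0.40 log units; beyond the scatter).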

Compound 3, half-maximal cytotoxic concentration: 18000 nM
Beside the measured number, compound 3's estimate is 2.8-fold (0.44 log units) above it; measured number below the stated range.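

At this aromatic carbon of the fused system, fluoro and chloro are not separated in this assay (a 1.1-fold lower number from compound 2 to compound 3 (0.05 log units; within the scatter)), so the exchange leaves the read-out within the scatter. The change that moves the read-out is instead chloro in place of hydrogen on an aromatic carbon (an at least 5.5-fold lower number from compound 1 to compound 3 (0.74 log units; beyond the scatter)). The value of compound 1 is a limit of the assay and not a number: the limit of > 100000 nM in this assay, at which 1 of the 3 values shown sits.

From the compounds shown here alone, whether a methoxy group or an amine at the same fused-system carbon would behave like fluoro and chloro remains open. Going by these compounds, the effect of fluoro or a methyl group in place of the chloro introduced from compound 1 to compound 3 also remains open.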